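This account rests on a few compounds, and the source may have more. Where it says the series, first, only, none or still open, it means among the compounds named here.

Measured compounds, an assay on CHO-K1 cells for inhibition of 11-beta-hydroxysteroid dehydrogenase type 2 (Homo sapiens), read by scintillation proximity assay; on this read-out higher numbers stand for weaker inhibition and lower numbers for stronger inhibition:
compound 1 `Cn1c(-c2ccccc2C(F)(F)F)nnc1C12CCC(CCS(=O)(=O)C(C)(C)C)(CC1)CC2`: > 4000 nM, a limit of the assay
compound 2 `CCS(=O)(=O)CCCCC12CCC(c3nnc(-c4ccccc4C(F)(F)F)n3C)(CC1)CC2`: > 4000 nM, a limit of the assay

Compound 2 stands at the limit of this assay, not at a number. Compound 1 stands at the same limit. Among the measured compounds shown here, the single step within the measured pair, a step that the two limits leave unreadable from compound 1 to compound 2, therefore cannot be read in either direction. Both values sit at the limit of > 4000 nM in this assay, at which 2 of the 2 values shown sit, so the two measured compounds show only that neither reaches a measurable inhibition here.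

Compound 3 `CCCCCC12CCC(c3nnc(-c4ccccc4C(F)(F)F)n3C)(CC1)CC2` has not been measured in this assay. It differs from compound 2 by methyl in place of ethylsulfonyl on a saturated chain carbon, four bonds along the chain from a saturated ring carbon. For the measured compounds named here, no measured step bears on this change in a readable way: the change from compound 1 to compound 2 alters the same chain, but its size is hidden by the two limits. With both measured variants of that chain at the limit, the step expected is a step that the limit leaves unreadable from compound 2 to compound 3, nothing beyond the scatter, and a further limit is the most likely outcome. For compound 3 the expected value is 6000 nM, with a range of 1500 nM to 30000 nM.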

Compound 3, half-maximal inhibitory concentration: 1300 nM
Compound 3: middle estimate off by 4.6-fold (0.66 log units), on the high side, outside the stated range (below it).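

In this assay, among the compounds shown here, methyl in place of ethylsulfonyl on a saturated chain carbon, four bonds along the chain from a saturated ring carbon, gives the first readable step: an at least 3.0-fold lower number from compound 2 to compound 3 (0.48 log units; beyond the scatter). Propyl in place of (tert-butyl)sulfonyl on a saturated chain carbon, two bonds along the chain from a saturated ring carbon, gives a second readable step: an at least 3.0-fold lower number from compound 1 to compound 3 (0.48 log units; beyond the scatter). For the compounds shown here, of the three chains on the shared core, only the one with no sulfonyl group, in compound 3, reaches a number, 1300 nM, so the chain at this position can change the read-out, which the two sulfonyl compounds alone could not show.

The step between the two sulfonyl compounds cannot be read, and the two new steps give only a minimum size, since compound 1 and compound 2 both sit at a limit: the limit of > 4000 nM in this assay, at which 2 of the 3 values shown sit. Going by these compounds, it remains open whether the sulfonyl group or the chain as a whole governs the read-out, and a shorter or longer plain alkyl chain, or a chain ending in an ether or an amine, would bear on that.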